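Chloro for methyl on a benzamide thioether

This account rests on a few compounds, and the source may have more. Where it says the series, first, only, none or still open, it means among the compounds named here.

Measured compounds:
compound 1, `Nc1ccccc1NC(=O)c1ccc(CSc2nccc(C(F)(F)F)n2)cc1`: 1140 nM
compound 2, `Cc1ccc(SCc2ccc(C(=O)Nc3ccccc3N)cc2)cc1`: 4250 nM
compound 3, `Nc1ccccc1NC(=O)/C=C/c1ccc(CSc2cccc3ccccc23)cc1`: "not determined" (no result reported)

The three compounds were tested in a functional assay on HeLa cells (Homo sapiens) for antiproliferative activity, read by CCK-8 assay, with a stated time of 72 h; on this read-out lower numbers stand for stronger inhibition and higher numbers for weaker inhibition. In this assay compound 1 gives 1140 nM, and compound 2 gives 4250 nM, the higher of the two numbers, so compound 2 stands as the weaker inhibitor of the pair, with a gap to compound 1 that lies beyond the scatter. For compound 3 this assay records "not determined" (no result reported), so no number is available for it.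

Compound 4, `Nc1ccccc1NC(=O)c1ccc(CSc2ccc(Cl)cc2)cc1`, has not yet been measured. It differs from compound 2 in one place: chloro in place of methyl on an aromatic carbon. Cut one bond further out, this reads as (4-methylphenyl)sulfanyl becoming (4-chlorophenyl)sulfanyl. Within the data shown here, no step between two measured compounds shows this change, so there is no direct guide to its size here. The author expects a step in this assay that stays within the scatter, with a slight lean toward a lower number.

For compound 4 the estimate is 3000 nM, with a range from 1200 nM to 7500 nM. This estimate means a step of a 1.4-fold lower number from compound 2 to compound 4 (0.15 log units; within the scatter), expected to remain inside the scatter.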

Compound 4, half-maximal inhibitory concentration: 12700 nM
The estimate for compound 4 lay 4.2-fold (0.63 log units) below the measured number; measured number outside the range, above it.
By their numbers in this assay, from the lowest: compound 1; then compound 2; then compound 4.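

Among these compounds, the earlier compounds offered no step between two structures differing in one place, so this is the first direct reading of a single change on this ring: in this assay, chloro in place of methyl gives a 3.0-fold higher number from compound 2 to compound 4 (0.48 log units; beyond the scatter). It shows that this aromatic carbon, para to a large group, is not indifferent to the exchange of one heavy atom for another, even though no ring, hydrogen-bond donor, hydrogen-bond acceptor or net charge enters or leaves, and here chloro goes with the weaker inhibition. Nothing among the available data accounts for the size or direction of this step.

From the compounds shown here alone, it remains open whether the rise in the number is particular to chloro or whether other groups on the same carbon, such as fluoro, methoxy, an amine or simply hydrogen, would stay nearer to methyl or move further from it. Whether the same exchange of methyl for chloro would produce a step of similar size and direction on a different core also remains unsettled.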